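The source may report more compounds than this note shows. Statements on the series, on what has been measured and on what is new or still open speak of the compounds shown alone.

Of the compounds shown here, three of one shared core have been measured so far, all of them in a functional assay on MCF7 cells (Homo sapiens) for antiproliferative activity, read by MTT assay, with a stated time of 24 h, tested at 100 uM; on this read-out higher numbers stand for a weaker effect at the one concentration tested and lower numbers for a stronger effect. Compound 1, `OC(CCn1nc2c(Br)c(Br)c(Br)c(Br)c2n1)c1ccc(F)cc1`, gives 0%. Compound 2, `C[C@@H](O)CCn1nc2c(Br)c(Br)c(Br)c(Br)c2n1`, gives 18%. Compound 3, `OC(CCn1nc2c(Br)c(Br)c(Br)c(Br)c2n1)c1ccccc1`, gives 13%. On these three numbers compound 3 stands second highest: its nearest neighbour is compound 2, within the scatter of it, and its furthest is compound 1, beyond the scatter and lower. For the measured compounds named here, the only single-point step measured so far runs a number 13 percentage points higher from compound 1 to compound 3 (beyond the scatter), a modest change for a hydrogen in place of fluoro on an aromatic carbon.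

The step now followed leads from compound 3 to compound 4, `CC(O)CCn1nc2c(Br)c(Br)c(Br)c(Br)c2n1`. The change is methyl in place of phenyl on a saturated chain carbon bound to an oxygen on a saturated carbon and a saturated chain carbon. Going by the values given here, no measured step swaps a phenyl for a methyl, so the fluoro step is no direct guide here. What does bear on it is compound 2, which already carries a methyl on a saturated chain carbon bound to an oxygen on a saturated carbon and a saturated chain carbon and gives 18%, a number within the scatter of compound 3. Compound 4 is therefore expected to land near that, with a step of a number 5 percentage points higher from compound 3 to compound 4 (within the scatter) expected, not beyond the scatter. The estimate for compound 4 is 18%, expected between 8% and 28%.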

Compound 4, a percentage reported as activity, at one concentration (the size of the read-out at that concentration, not a potency): 57%
Estimate against measurement, compound 4: 39 percentage points below; measured number outside the range, above it.
By their numbers in this assay, from the lowest: compound 1; then compounds 3 and 2 (each within the scatter of the next); then compound 4.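

In this assay this place on the chain turns out to be sensitive: methyl in place of phenyl gives a number 44 percentage points higher from compound 3 to compound 4 (beyond the scatter), and methyl in place of 4-fluorophenyl gives a number 57 percentage points higher from compound 1 to compound 4 (beyond the scatter), so both aromatic compounds show a stronger effect than compound 4 at the one concentration tested. Compound 2 goes against reading this as a simple rule about the methyl group, for it carries the same methyl and still shows a number 39 percentage points higher from compound 2 to compound 4 (beyond the scatter). That pair has the same atoms and bonds, with the stereocentre drawn R in compound 2 and without a configuration in compound 4, so the large gap may be due to the configuration, though the drawing alone cannot settle this: the fact that one of compounds 2 and 4 is drawn with a defined configuration and the other without, at the place where they differ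

The compounds shown do not tell which configuration or mixture of configurations compound 4 contains, nor how compound 1 and compound 3, also drawn without a configuration, would behave as single forms. On these data alone, it also remains open how an amine, a carboxylic acid or a longer chain at this place would compare with methyl and phenyl.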